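Compound 3 to compound 4: loss of (1-bromoethenyl)carbonyl

A few compounds are considered here, and "the series" means these few. Any claim that something is new, unique, unknown or untested is made for them only; others in the source may bear on it.

Measured in an ADME assay on CCRF-CEM cells (Homo sapiens) for antiproliferative activity, with a stated time of 48 h; a higher number here means a weaker inhibitor, a lower number a stronger inhibitor:
- compound 1 `C=C(Br)C(=O)Nc1ccc(/C=C/C(=O)c2ccc(Cl)c(Cl)c2)cc1` gives 1700 nM
- compound 2 `C=C(Br)C(=O)Nc1ccc(/C=C/C(=O)c2ccc(I)cc2)cc1` gives 4000 nM
- compound 3 `C=C(Br)C(=O)Nc1ccc(/C=C/C(=O)c2ccc(OC)cc2)cc1` gives 1400 nM

Compound 3 has the lowest number of the three, but it cannot be separated from compound 1, as a 1.2-fold lower number from compound 1 to compound 3 (0.08 log units; within the scatter) shows. It stands clear only of compound 2, with a 2.9-fold lower number from compound 2 to compound 3 (0.46 log units; beyond the scatter).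

The next structure is compound 4 `COc1ccc(C(=O)/C=C/c2ccc(N)cc2)cc1`, and the change is hydrogen in place of (1-bromoethenyl)carbonyl on a nitrogen on an aromatic ring. In words, this is hydrogen in place of (1-bromoethenyl)carbonyl on a nitrogen on an aromatic ring.

The measured steps bear on this only indirectly. All of them alter the other end of the molecule, and the largest, a 2.9-fold lower number from compound 2 to compound 3 (0.46 log units; beyond the scatter) and a 2.4-fold higher number from compound 1 to compound 2 (0.37 log units; beyond the scatter), are modest. All three measured compounds carry the departing group, so the data hold no direct measure of its loss. A higher number in this assay is therefore a judgement, held with a wide margin.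

The expected step is a 6.4-fold higher number from compound 3 to compound 4 (0.81 log units; beyond the scatter).

The estimated value for compound 4 is 9000 nM, with an expected range of 3000 nM to 30000 nM.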

Compound 4, half-maximal inhibitory concentration: 37000 nM
For compound 4 the middle estimate is 4.1-fold (0.61 log units) below the measured one, and the stated range ends below it.
By their numbers in this assay, from the lowest: compounds 3 and 1 (each within the scatter of the next); then compound 2; then compound 4.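

In this assay, a 26-fold higher number from compound 3 to compound 4 (1.42 log units; beyond the scatter) is the only step shown at the nitrogen on an aromatic ring, and it is large, whereas the steps among compounds 1, 2 and 3, which all keep the (1-bromoethenyl)carbonyl, are modest or within the scatter. In this one pair, removing the (1-bromoethenyl)carbonyl to leave the amino group therefore moves the antiproliferative read-out much further than any change of aryl group on the carbonyl carbon seen so far. No measurement at hand accounts for the size of this step.

On these data alone, whether the step depends on the bromine or on the acyl group as a whole remains open, and an acryloyl or acetyl on the same nitrogen would separate the two. Also open, as far as these compounds go, is whether the loss is of similar size with 3,4-dichlorophenyl or 4-iodophenyl on the carbonyl carbon.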